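The source may hold more compounds than are shown below. What is called first, only, known or untested is meant among the compounds shown, and "the series" means these compounds.

Compound 1 `CN(C)C(=O)C1CCN(c2cnccc2-n2cccn2)CC1` and compound 2 `CN(C)C(=O)C1CCN(c2cnccc2-n2cc(Br)cn2)CC1` share one core and differ only on the five-membered aromatic ring. In an assay on HEK293F cells for inhibition of cholesterol 24-hydroxylase (Homo sapiens), read by trypan blue exclusion, with stated times of 15 min and 5 h (on this read-out higher numbers stand for weaker inhibition and lower numbers for stronger inhibition), compound 1 gives 48 nM, while compound 2 gives 9.5 nM. Among the compounds with values here, that single change, a 5.1-fold lower number from compound 1 to compound 2 (0.70 log units; beyond the scatter), is the only measured step in the set, and it places compound 2 at the lowest of the two numbers known. Compound 3 `CN(C)C(=O)C1CCN(c2cnccc2-n2cc(C3CC3)cn2)CC1` takes the next step: cyclopropyl in place of bromo on an aromatic carbon. Within the data shown here, no measured pair reports a swap of bromo for cyclopropyl, so the expectation rests on the fact that compound 2 shows a group at this place to be tolerated and even favoured relative to compound 1. A step of modest size in either direction, or none beyond the scatter, is therefore expected in this assay, with a slight lean toward a somewhat higher number for compound 3 a 1.5-fold higher number from compound 2 to compound 3 (0.17 log units; within the scatter). Compound 3 is estimated at 14 nM, within 4 nM to 45 nM.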

Compound 3, half-maximal inhibitory concentration: 12 nM
Compound 3: the middle estimate sits 1.2-fold (0.07 log units) above what was measured; measured number inside the range.
By their numbers in this assay, from the lowest: compounds 2 and 3 (each within the scatter of the next); then compound 1.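

At this aromatic carbon of the five-membered aromatic ring, this assay does not separate cyclopropyl from bromo: a 1.3-fold higher number from compound 2 to compound 3 (0.10 log units; within the scatter), and this step stays within the scatter. The advantage over hydrogen at this place therefore does not depend on a halogen in these compounds, since a group of carbon only, bearing a three-membered ring, also gives a 4.0-fold lower number from compound 1 to compound 3 (0.60 log units; beyond the scatter), a step beyond the scatter and of modest size. Nothing measured here speaks to why bromo and cyclopropyl read alike.

The compounds shown leave open how a longer alkyl chain or a phenyl group would read at this carbon. They also leave open whether a group carrying nitrogen or oxygen, such as an amine, a methoxy or a nitrile, would keep the number of compound 3 or lose it.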